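Ring methyl on the benzyl arm: compound 2 to compound 4

The source may report more compounds than this note shows. Statements on the series, on what has been measured and on what is new or still open speak of the compounds shown alone.

Compound 1 `Cc1noc(C)c1-c1ccc2c(c1)c(Cc1ccccc1)cn2CCCCCC(=O)NO` gives 15500 nM in a functional assay on THP-1 cells (Homo sapiens) for inhibition; on this read-out higher numbers stand for weaker inhibition of growth and lower numbers for stronger inhibition of growth. Compound 2 `Cc1noc(C)c1-c1ccc2c(c1)c(Cc1ccccc1)cn2CCCCCCC(=O)NO` gives 15500 nM in this assay, and compound 3 `Cc1noc(C)c1-c1ccc2c(c1)c(CCc1ccc(F)cc1)cn2CCCCCC(=O)NO` gives 15500 nM in this assay. Compound 2 thus stands level with compound 1 and compound 3 at the digits shown. The step of no change at the digits printed from compound 1 to compound 2 (within the scatter) and the step of no change at the digits printed from compound 1 to compound 3 (within the scatter) both stayed within the scatter. Compound 4 `Cc1ccccc1Cc1cn(CCCCCCC(=O)NO)c2ccc(-c3c(C)noc3C)cc12` differs from compound 2 by methyl in place of hydrogen on an aromatic carbon. For the measured compounds named here, no measured step alters the benzyl ring itself; the closest comparison is the change on the same arm from compound 1 to compound 3, which gave no change at the digits printed from compound 1 to compound 3 (within the scatter). The expected step of no change at the digits printed from compound 2 to compound 4 (within the scatter) is therefore none beyond the scatter. Compound 4 is estimated at 15500 nM, with a range of 7000 nM to 31000 nM.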

Compound 4, concentration for 50% growth inhibition: 15500 nM
For compound 4 middle estimate and measured number coincide at the digits printed; measured number inside the range.
By their numbers in this assay, from the lowest: compounds 1, 2, 3 and 4 (each within the scatter of the next).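

Benzyl to 2-methylbenzyl is the first reading on the benzyl ring itself, and in this assay it gives no change at the digits printed from compound 2 to compound 4 (within the scatter). Methyl on this aromatic carbon, ortho to a large group, therefore leaves compound 4 level with compounds 1, 2 and 3. No measurement here bears on why the values stay level.

Still open, going by these compounds, is whether a larger group on this carbon, such as an amine or a carboxylic acid, would separate from compound 2. Methyl at other carbons of this ring also remains open.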